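A methoxyphenyl swap on one ring carbon

The compounds below may be only part of what the source reports. "The series", "measured", "known", "first", "only" and "open" are said of these compounds alone.

Compound 1 `COc1ccc(C2=C(c3ccc(SC)cc3)CC3CCCN3C2=O)cc1O`: 5000 nM
Compound 2 `CSc1ccc(C2=C(c3ccc(C)c(C)c3)C(=O)N3CCCC3C2)cc1`: 800 nM
Compound 3 `CSc1ccc(C2=C(c3ccc(F)c(C)c3)C(=O)N3CCCC3C2)cc1`: 500 nM

These values come from a functional assay on MCF-A cells (Homo sapiens) for cytotoxicity; on this read-out higher numbers stand for weaker inhibition of growth and lower numbers for stronger inhibition of growth. Two compounds share the low end of the numbers: a 1.6-fold lower number from compound 2 to compound 3 (0.20 log units; within the scatter). The gap to the high end is wider: a 10-fold lower number from compound 1 to compound 3 (1.00 log units; beyond the scatter).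

Compound 4 `COc1ccc(C2=C(c3ccc(SC)cc3)CC3CCCN3C2=O)cc1` brings one change: 4-methoxyphenyl in place of 4-fluoro-3-methylphenyl on a double-bonded ring carbon. The closest guide is the 3-hydroxy-4-methoxyphenyl group, which also carries a 4-methoxy and sits on that carbon: a 6.3-fold lower number from compound 1 to compound 2 (0.80 log units; beyond the scatter). The entering group lacks the hydroxy, so only part of that modest gap is expected to return in this assay. The expected size is a 2.4-fold higher number from compound 3 to compound 4 (0.38 log units; beyond the scatter). For compound 4 the estimate is 1200 nM, with an expected range of 350 nM to 4000 nM.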

Compound 4, concentration for 50% growth inhibition: 5000 nM
Compound 4: middle estimate off by 4.2-fold (0.62 log units), on the low side, outside the stated range (above it).
By their numbers in this assay, from the lowest: compounds 3 and 2 (each within the scatter of the next); then compounds 1 and 4 (each within the scatter of the next).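

In this assay, the hydroxy makes no difference on this ring: there is no change at the digits printed from compound 1 to compound 4 (within the scatter). The high number therefore goes with the 4-methoxyphenyl group whether or not the hydroxy is present, as the steps to the methyl-bearing rings show: a 10-fold higher number from compound 3 to compound 4 (1.00 log units; beyond the scatter) and a 6.3-fold higher number from compound 2 to compound 4 (0.80 log units; beyond the scatter). Nothing available explains this difference. Compounds 2 and 3 both carry a 3-methyl group that compound 4 lacks, so the loss of that methyl cannot be separated from the arrival of the methoxy. A plain phenyl or a 3-methylphenyl group on this carbon would address that, and a 4-aminophenyl group would test another substituent there.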